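The source may report more compounds than this note shows. Statements on the series, on what has been measured and on what is new or still open speak of the compounds shown alone.

Of the compounds shown here, three built on one shared core have been tested in a functional assay on HEK293 cells for agonist activity at G-protein coupled receptor 39 (Homo sapiens), read by scintillation proximity assay and inositol phosphate accumulation, with a stated time of 75 min, in the presence of a further agent that is not named here; a lower number here means that less compound is needed, a higher number that more compound is needed for the effect. Compound 1 `Cc1nn(-c2ncnc3nc[nH]c23)c2c1C(OCc1ccc(Cl)cc1Cl)CC(=O)N2` gives 4 nM. Compound 2 `Cc1nn(-c2ncnc3nc[nH]c23)c2c1C(C(=O)Nc1ccccc1)CC(=O)N2` gives 10 nM, and compound 3 `Cc1cc(C)n(CCOC2CC(=O)Nc3c2c(C)nn3-c2ncnc3nc[nH]c23)n1` gives 16 nM. Compound 2 therefore holds the second highest of the three numbers: the step of a 2.5-fold higher number from compound 1 to compound 2 (0.40 log units; beyond the scatter) lies beyond the usual scatter, while the step of a 1.6-fold higher number from compound 2 to compound 3 (0.20 log units; within the scatter) lies within it.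

Compound 4 `Cc1nn(-c2ncnc3nc[nH]c23)c2c1C(NC(=O)Cc1cccs1)CC(=O)N2` is the next member of the series. It differs from compound 2 in a single place: (((thiophen-2-yl)methyl)carbonyl)amino in place of phenylcarbamoyl on a saturated ring carbon. Both measured steps touch the same saturated ring carbon. The step of a 2.5-fold higher number from compound 1 to compound 2 (0.40 log units; beyond the scatter) was modest, and the step of a 1.6-fold higher number from compound 2 to compound 3 (0.20 log units; within the scatter) was too small to count, so swapping groups at this position has so far moved the numbers only a little. A small step in the same direction is expected, a 1.5-fold higher number from compound 2 to compound 4 (0.18 log units; within the scatter), within or near the scatter. Compound 4 is therefore estimated at 15 nM in this assay, with a likely range from 6 nM to 40 nM.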

Compound 4, half-maximal effective concentration: 3 nM
Beside the measured number, compound 4's estimate is 5.0-fold (0.70 log units) above it; measured number below the stated range.
By their numbers in this assay, from the lowest: compounds 4 and 1 (each within the scatter of the next); then compounds 2 and 3 (each within the scatter of the next).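

Placing (((thiophen-2-yl)methyl)carbonyl)amino on this saturated ring carbon instead of phenylcarbamoyl gives a 3.3-fold lower number from compound 2 to compound 4 (0.52 log units; beyond the scatter) and shows that here an amide joined through its nitrogen can outperform one joined through its carbonyl. The same group gives a 5.3-fold lower number from compound 3 to compound 4 (0.73 log units; beyond the scatter) as the widest step yet at this position, while a 1.3-fold lower number from compound 1 to compound 4 (0.12 log units; within the scatter) shows that a group without the chlorines of compound 1 can reach the same level. Nothing measured here explains these differences.

From the compounds shown here alone, the change from compound 2 to compound 4 reverses the amide and replaces the phenyl ring with a thiophene ring on a one-carbon link, so the contribution of each remains unknown. Going by these compounds, how a phenylacetylamino group or a plain acetylamino group would behave on this carbon remains open, and either could help separate those contributions.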